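Sulfanyl for methoxy on the five-membered ring

The compounds below may be only part of what the source reports. "The series", "measured", "known", "first", "only" and "open" are said of these compounds alone.

Measured so far:
compound 1 `COc1nc2c(N)ncnc2n1Cc1ccccc1` > 10 uM
compound 2 `CCCC[S+]([O-])c1nc(N)c2nc(O)n(Cc3ccccc3)c2n1` 0.01 uM
compound 3 `Nc1nc(S)nc2c1nc(O)n2Cc1ccccc1` 10 uM

In a functional assay (spleen, spleen) for activation, with Mus musculus as the target (on this read-out lower numbers stand for an effect already at smaller amounts and higher numbers for an effect only at larger amounts of compound), compound 1 stands only at a limit of the assay, > 10 uM, with no number behind it (the limit of > 10 uM in this assay, at which 1 of the 3 values shown sits). Compound 2 gives 0.01 uM and compound 3 gives 10 uM in this assay. For the measured compounds named here, the one measured step, a 1000-fold higher number from compound 2 to compound 3 (3.00 log units; beyond the scatter), exchanges a group on a different part of the core than the change taken here, so it does not bear directly on compound 4.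

Compound 4 `Nc1ncnc2c1nc(S)n2Cc1ccccc1` differs from compound 1 in one place: sulfanyl in place of methoxy on an aromatic carbon. Going by the values given here, no measured pair changes the group at this place, so the step can only be framed by the standing of compound 1 at its limit and by the number of compound 3, whose core also carries a sulfanyl. A step from compound 1 to compound 4 is expected to stay small, a number no higher from compound 1 to compound 4 (the limit leaves the size open), with a real chance that only a limit is returned again. Compound 4 is therefore estimated at 10 uM in this assay, within 2 uM to 50 uM.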

Compound 4, minimum effective concentration: 10 uM
Beside the measured number, compound 4's estimate shows no gap at the digits printed, within the range that was stated.
By their numbers in this assay, from the lowest: compound 2; then compounds 3 and 4 (each within the scatter of the next).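

In this assay, sulfanyl in place of methoxy on the aromatic carbon of the five-membered aromatic ring gives a number no higher from compound 1 to compound 4 (the limit leaves the size open). For the compounds shown here, with this change the place carries a readable number for the first time, as compound 4 gives 10 uM, so a group at this place can be compared by value from here on. Compound 1 stands at a limit and not at a number, so no gain can be read from this step: the limit of > 10 uM in this assay, at which 1 of the 4 values shown sits.

The compounds shown offer no pair with numbers on both sides at this place, so the size of the change from methoxy to sulfanyl stays open. On these data alone, how an amine, a carboxylic acid or a longer chain on this same aromatic carbon would read in this assay also stays open.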